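A few compounds are considered here, and "the series" means these few. Any claim that something is new, unique, unknown or untested is made for them only; others in the source may bear on it.

Measured so far:
- compound 1 `CC1=C(C(=O)OC2CCCCC2)C(c2ccc3c(c2)OCCO3)C2=C(CC(C)(C)CC2=O)N1`: 12300 nM
- compound 2 `CC1=C(C(=O)OCC2CCN(C(=O)OC(C)(C)C)CC2)[C@@H](c2cccc(Br)c2)C2=C(CC(C)(C)CC2=O)N1`: 2590 nM

Compound 1 is the structure `CC1=C(C(=O)OC2CCCCC2)C(c2ccc3c(c2)OCCO3)C2=C(CC(C)(C)CC2=O)N1` and, in an assay on HEK293 cells for inhibition of neurogenic locus notch homolog protein 1 (Homo sapiens), read by a luciferase reporter and resazurin assay, with a stated time of 16 h (a lower number here means a stronger inhibitor, a higher number a weaker inhibitor), compound 1 gives 12300 nM. Compound 2 is the structure `CC1=C(C(=O)OCC2CCN(C(=O)OC(C)(C)C)CC2)[C@@H](c2cccc(Br)c2)C2=C(CC(C)(C)CC2=O)N1`, and in this assay compound 2 gives 2590 nM, the lower of the two numbers recorded; compound 1 sits at a number that is beyond the usual scatter above it. Going by the values given here, no pair among the measured compounds differs in a single place, so no measured step is available to lean on.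

Compound 3 is the structure `CC1=C(C(=O)OCC2CCN(C(=O)OC(C)(C)C)CC2)[C@H](c2cccc(Br)c2)C2=C(CC(C)(C)CC2=O)N1`. It differs from compound 2 in this way: the two compounds have the same atoms and bonds and differ only in configuration as drawn: 1 of 1 stereo elements differ; a stereocentre at a saturated ring carbon is drawn S in compound 2 and R in compound 3. Compound 2 and compound 3 are therefore mirror images of each other, with nothing added and nothing taken away.

With no measured pair of mirror images to compare, the size of the step cannot be read from the numbers shown. Such pairs often differ in potency, and the more common outcome is that one mirror image is clearly weaker than the other. Since compound 2 already stands at the lower number, the expected step from compound 2 to compound 3 is a 2.7-fold higher number from compound 2 to compound 3 (0.43 log units; beyond the scatter), towards a higher number in this assay, beyond the scatter but with wide uncertainty. Compound 3 is accordingly expected to give about 7000 nM in this assay, within a range from 1200 nM to 40000 nM.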

Compound 3, half-maximal inhibitory concentration: 130 nM
Compound 3: middle estimate off by 54-fold (1.73 log units), on the high side; measured number outside the range, below it.
By their numbers in this assay, from the lowest: compound 3; then compound 2; then compound 1.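

In this assay, the configuration at one saturated ring carbon turns out to matter a great deal: going from the S form to the R form gives a 20-fold lower number from compound 2 to compound 3 (1.30 log units; beyond the scatter). Compound 1 and compound 2 differ in several places at once, so they could not tie a change in the number to any single feature, whereas this pair isolates one feature and shows that the R form carries the lower number. With no atom added or removed, the gap can be traced to that stereocentre alone, because of a single fact about the pair: the fact that compounds 2 and 3 differ only in the configuration as drawn

Only this one pair of mirror images is shown, so it remains open whether the R form would keep its advantage on a different ester side chain, such as the cyclohexyl ester of compound 1, or with the bromine replaced by another group, such as a nitrile. Also open, on these data alone, is how the number would respond if the ester side chain carried a free amine or a carboxylic acid.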